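The source may hold more compounds than are shown below. What is called first, only, known or untested is meant among the compounds shown, and "the series" means these compounds.

Within this set of three measured compounds, compound 2 `CC1(C)Oc2ccc(C#N)cc2[C@H](Nc2ccccc2)[C@H]1O` is the only one with a numeric reading: in a functional assay (aorta) with Rattus norvegicus as the target (on this read-out lower numbers stand for stronger inhibition and higher numbers for weaker inhibition), compound 2 gives 1200 nM. Compound 1 `CCOC(=O)CN(c1ccccc1)[C@@H]1c2cc(C#N)ccc2OC(C)(C)[C@H]1O` is reported only as > 30000 nM, which is a limit of this assay and not a number. Compound 3 `CCOC(=O)CN(c1ccc(Cl)cc1)[C@H]1c2cc(C#N)ccc2OC(C)(C)[C@@H]1O` likewise is reported only as > 30000 nM, again a limit and not a number. Going by the values given here, no single-point step between measured compounds is available, so compound 2 stands alone as the reference point, with the limit of > 30000 nM in this assay, at which 2 of the 3 values shown sit, marking where the other two sit.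

Compound 4 `CC1(C)Oc2ccc(C#N)cc2[C@H](N(CC#N)c2ccccc2)[C@H]1O` is the next member to be measured. It differs from compound 2 by cyanomethyl in place of hydrogen on a nitrogen on an aromatic ring. Since both substituted-nitrogen analogues rest at the limit of > 30000 nM in this assay, at which 2 of the 3 values shown sit, the expectation for this step is a weakening beyond the scatter rather than a gain. Compound 4 is therefore estimated at 8000 nM, with a range from 2000 nM to 30000 nM. That estimate corresponds to an expected shift of a 6.7-fold higher number from compound 2 to compound 4 (0.82 log units; beyond the scatter), with a real chance that only a limit is reported.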

Compound 4, half-maximal inhibitory concentration: 59000 nM
Beside the measured number, compound 4's estimate is 7.4-fold (0.87 log units) below it, outside the stated range (above it).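

In this assay, replacing the hydrogen on the nitrogen on an aromatic ring with cyanomethyl gives a 49-fold higher number from compound 2 to compound 4 (1.69 log units; beyond the scatter). Going by these compounds alone, this is the first size that can be put on a change at this position, and it shows that, for this one group, the hydrogen-bearing nitrogen of compound 2 goes with the stronger inhibition. Compounds 1 and 3 add no size to this picture, since each is reported only as a limit and not a number: the limit of > 30000 nM in this assay, at which 2 of the 4 values shown sit.

A single step cannot separate the loss of the nitrogen hydrogen from the arrival of the cyanomethyl group itself. Going by these compounds, whether a methyl, a longer alkyl chain or a chain ending in a carboxylic acid on this nitrogen would carry the same cost remains open.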